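Urea series: nitro in place of iodo at the aryl terminus

The compounds below may be only part of what the source reports. "The series", "measured", "known", "first", "only" and "open" are said of these compounds alone.

Measured so far in a functional assay on CRL2813 cells (Homo sapiens) for cytotoxicity, read by sulforhodamine B assay, with a stated time of 5 days; a higher number here means a weaker inhibitor, a lower number a stronger inhibitor:
Compound 1 `O=C(Nc1cccc(C(=O)O)c1)N[C@H]1CC[C@H](Oc2ccc(F)cc2)CC1` sits at the assay limit, > 20000 nM.
Compound 2 `COC(=O)c1ccc(NC(=O)N[C@H]2CC[C@H](Oc3ccc(F)cc3)CC2)cc1` gives 11600 nM.
Compound 3 `O=C(Nc1ccc(I)cc1)N[C@H]1CC[C@H](Oc2ccc(F)cc2)CC1` gives 10200 nM.

Compound 3 has the lowest of the two numbers, with compound 2 nearest; the two lie within the scatter of each other, so no order between them is claimed. The limit of compound 1 is only a limit, noted as the limit of > 20000 nM in this assay, at which 1 of the 3 values shown sits.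

The next compound is compound 4 `O=C(Nc1ccc([N+](=O)[O-])cc1)N[C@H]1CC[C@H](Oc2ccc(F)cc2)CC1`. It differs from compound 3 by nitro in place of iodo on an aromatic carbon.

Among the compounds with values here, two measured steps bear on this change. The step of a 1.1-fold lower number from compound 2 to compound 3 (0.06 log units; within the scatter) exchanges one group on the same aromatic carbon and stays within the scatter. The step of an at least 1.9-fold lower number from compound 1 to compound 3 (0.29 log units; that floor lies within the scatter) only reaches a floor that itself lies within the scatter. Neither step shows that a group on that aromatic carbon moves this assay beyond the scatter, so for compound 4 no step beyond the scatter is expected in either direction; the expected step is a 1.0-fold lower number from compound 3 to compound 4 (0.01 log units; within the scatter). Compound 4 is therefore estimated at 10000 nM, with a range from 4000 nM to 25000 nM.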

Compound 4, half-maximal inhibitory concentration: 2300 nM
Beside the measured number, compound 4's estimate is 4.3-fold (0.64 log units) above it; the whole stated range lies above it.
By their numbers in this assay, from the lowest: compound 4; then compounds 3 and 2 (each within the scatter of the next). At a limit, above all of these: compound 1.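

In this assay, within the data shown here, the aryl terminus of this urea series now shows steps beyond the scatter, which the earlier compounds did not: a 4.4-fold lower number from compound 3 to compound 4 (0.65 log units; beyond the scatter) and a 5.0-fold lower number from compound 2 to compound 4 (0.70 log units; beyond the scatter). Iodo and methoxycarbonyl on this aromatic carbon stay within the scatter of each other, so the aromatic carbon para to a large group does respond to substitution, but among the groups shown only nitro separates. With compound 1 a limit and not a number, the step of an at least 8.6-fold lower number from compound 1 to compound 4 (0.93 log units; beyond the scatter) is only a floor, yet it passes the scatter: the limit of > 20000 nM in this assay, at which 1 of the 4 values shown sits.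

On these data alone, whether the shift is particular to nitro or is shared by other groups on this carbon, such as nitrile, trifluoromethyl or an amine, stays open. Nitro appears at one place on this ring only, so its effect elsewhere on the ring is also open.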